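Nitrophenyl in Place of Trifluoromethylphenyl on the Triazole Nitrogen

The compounds below may be only part of what the source reports. "The series", "measured", "known", "first", "only" and "open" are said of these compounds alone.

Of the compounds shown here, three sharing one core have been tested in a functional assay on HeLa cells (Homo sapiens) for inhibition, read by MTT assay, with a stated time of 24 h; a higher number here means a weaker inhibitor, a lower number a stronger inhibitor. Compound 1 `CCOC(=O)C1=Cc2ccccc2OC1(OCc1cn(-c2ccc(F)cc2)nn1)C(F)(F)F` carries a 4-fluorophenyl on an aromatic nitrogen, and in this assay compound 1 gives 8400 nM. Compound 2 `CCOC(=O)C1=Cc2ccccc2OC1(OCc1cn(CC(=O)Nc2ccccc2Br)nn1)C(F)(F)F` carries a ((2-bromophenyl)carbamoyl)methyl at that nitrogen. In this assay compound 2 reaches only the limit > 150000 nM, which is not a number. Compound 3 `CCOC(=O)C1=Cc2ccccc2OC1(OCc1cn(-c2cccc(C(F)(F)F)c2)nn1)C(F)(F)F` carries a 3-(trifluoromethyl)phenyl there. In this assay compound 3 likewise stands at the limit > 150000 nM, and no number is known for it. Both replacements of the 4-fluorophenyl weakened inhibition beyond the scatter: an at least 17-fold higher number from compound 1 to compound 2 (1.25 log units; beyond the scatter) and an at least 17-fold higher number from compound 1 to compound 3 (1.25 log units; beyond the scatter). Between the two limits, a step that the two limits leave unreadable from compound 2 to compound 3. Compound 3 thus sits at the limit of > 150000 nM in this assay, at which 2 of the 3 values shown sit.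

Compound 4 `CCOC(=O)C1=Cc2ccccc2OC1(OCc1cn(-c2ccc([N+](=O)[O-])cc2)nn1)C(F)(F)F` has not yet been measured. It differs from compound 3 in one place: 4-nitrophenyl in place of 3-(trifluoromethyl)phenyl on an aromatic nitrogen. Among the compounds with values here, no measured step involves a 4-nitrophenyl; the step that bears most closely on the change is the one on the same aromatic nitrogen, an at least 17-fold higher number from compound 1 to compound 3 (1.25 log units; beyond the scatter), which shows that a swap of the group at this position can move the result by a large amount. Compound 3 sits at a limit, and a step from it can only be read as a decrease or as nothing beyond the scatter. The expected number for compound 4 in this assay is 40000 nM, within 8000 nM to 150000 nM. This estimate means a step of an at least 3.7-fold lower number from compound 3 to compound 4 (0.57 log units; beyond the scatter).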

Compound 4, half-maximal inhibitory concentration: > 150000 nM
Compound 4: only a limit was reported; the forecaster's own chance of this, stated with the estimate: 40%; middle value at least 3.7-fold (0.57 log units) from the limit.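

Keeping the 4-position of the phenyl group and changing only the fluoro to a nitro gives an at least 17-fold higher number from compound 1 to compound 4 (1.25 log units; beyond the scatter) in this assay, so holding the substituent at that place does not by itself preserve a readable inhibition. Compound 3 had changed both the group and its place on the phenyl ring, whereas compound 4 shows that a change of the group alone is enough for a large loss. Of the four groups shown on this nitrogen, only the 4-fluorophenyl gives a number, the steps among compound 2, compound 3 and compound 4 cannot be read, and the value of compound 4 is again a limit and not a number: the limit of > 150000 nM in this assay, at which 3 of the 4 values shown sit.

On these data alone, the order of compound 2, compound 3 and compound 4 stays unknown, as does how far each lies from the limit. As far as these compounds go, it also remains open whether a plain phenyl, a 4-chlorophenyl or a 4-aminophenyl on this nitrogen would give a number near that of compound 1, or whether the fluoro is the only substituent here that does.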